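Bromo to dimethylamino on the chain carbon

The source may hold more compounds than are shown below. What is called first, only, known or untested is meant among the compounds shown, and "the series" means these compounds.

Among the compounds with values here, in a functional assay on A549 cells (Homo sapiens) for antiproliferative activity, read by MTT assay, with a stated time of 48 h (on this read-out lower numbers stand for stronger inhibition and higher numbers for weaker inhibition), compound 1 `COc1ccc(C(=O)c2ccc(OC)c3c2C=CC(C)(C)O3)c(NC(=O)CBr)c1` gives 2460 nM, the higher of the two numbers measured so far. Compound 2 `COc1ccc(C(=O)c2ccc(OC)c3c2OC(C)(C)C=C3)c(NC(=O)CN)c1` gives 270 nM, a lower number by a gap beyond the usual scatter, which puts compound 1 at the weak end of this small set. Compound 3 `COc1ccc(C(=O)c2ccc(OC)c3c2C=CC(C)(C)O3)c(NC(=O)CN(C)C)c1` keeps the core of compound 1 and changes one place: dimethylamino in place of bromo on a saturated chain carbon bound to a carbonyl carbon. Dimethylamino thus stands in place of bromo on a saturated chain carbon bound to a carbonyl carbon. Within the data shown here, no measured pair isolates this change, so the size of the step in this assay cannot be read directly. A step towards a lower number, beyond the scatter, is expected. This expectation rests on compound 2 at 270 nM, which shows that numbers well under that of compound 1 occur in the series, though not how much of that gap this change would recover. The expected step is a 4.1-fold lower number from compound 1 to compound 3 (0.61 log units; beyond the scatter). For compound 3 the estimated value is 600 nM, with an expected range of 150 nM to 2200 nM.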

Compound 3, half-maximal inhibitory concentration: 1850 nM
Compound 3: the middle estimate sits 3.1-fold (0.49 log units) below what was measured; the measured number falls inside the stated range.
By their numbers in this assay, from the lowest: compound 2; then compounds 3 and 1 (each within the scatter of the next).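

In this assay, within the data shown here, this pair is the first to isolate the position, and it gives a 1.3-fold lower number from compound 1 to compound 3 (0.12 log units; within the scatter) for dimethylamino in place of bromo on a saturated chain carbon bound to a carbonyl carbon. On the core of compound 1, exchanging this single bromine for a group of 3 heavy atoms, with 1 hydrogen-bond acceptor entering, therefore does not separate the two compounds on this read-out. No measurement available here speaks to the reason for this result.

Compound 2 differs from both compound 1 and compound 3 in more than one place, so its steps to them cannot be read, and its printed value cannot be assigned to the chain group alone. As far as these compounds go, it remains open whether amino on the core of compound 1, or a morpholine, a carboxylic acid or a longer chain at this saturated chain carbon, would give a step beyond the scatter.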